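Propargyl Amine Series: Adding Methoxy Groups to the Aryl Ring

A few compounds are considered here, and "the series" means these few. Any claim that something is new, unique, unknown or untested is made for them only; others in the source may bear on it.

Measured compounds:
Compound 1, `CCN(Cc1nc2cc(C(F)(F)F)ccc2nc1-c1ccccc1)c1cc(OC)c(OC)c(OC)c1`: 6000 nM
Compound 2, `C#CCN(Cc1nc2cc(C(F)(F)F)ccc2nc1-c1ccccc1)c1ccc(OC)cc1`: 3000 nM

In an assay on isolated protein for inhibition of Dihydrofolate reductase (Homo sapiens), read by spectrophotometry (on this read-out higher numbers stand for weaker inhibition and lower numbers for stronger inhibition), compound 1 gives 6000 nM, and compound 2 gives 3000 nM. These two values lie within the usual scatter of each other, so compound 2 cannot be set apart from compound 1 on this evidence; it simply serves as the starting point for the next step.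

Compound 3, `C#CCN(Cc1nc2cc(C(F)(F)F)ccc2nc1-c1ccccc1)c1cc(OC)c(OC)c(OC)c1`, has not been measured in this assay. It differs from compound 2 in one place: 3,4,5-trimethoxyphenyl in place of 4-methoxyphenyl on an amine nitrogen. Compound 1 already carries the same 3,4,5-trimethoxyphenyl group together with a different chain on the amine nitrogen, and its value sits within the scatter of compound 2, so no clear direction is indicated. The step from compound 2 to compound 3 is therefore expected to be small, estimated as a 1.3-fold higher number from compound 2 to compound 3 (0.12 log units; within the scatter). Compound 3 is expected to give about 4000 nM, within a range from 1500 nM to 12000 nM.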

Compound 3, inhibition constant: 4000 nM
Beside the measured number, compound 3's estimate shows no gap at the digits printed; measured number inside the range.
By their numbers in this assay, from the lowest: compounds 2, 3 and 1 (each within the scatter of the next).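

In this assay, 3,4,5-trimethoxyphenyl in place of 4-methoxyphenyl on an amine nitrogen gives a 1.3-fold higher number from compound 2 to compound 3 (0.12 log units; within the scatter), so at this position the group of 12 heavy atoms cannot be told apart from the group of 8 heavy atoms. For the compounds shown here, compound 3 also gives the first direct reading of the chain on that nitrogen with the 3,4,5-trimethoxyphenyl group held fixed: ethynyl in place of methyl on a saturated chain carbon bound to a nitrogen on an aromatic ring gives a 1.5-fold lower number from compound 1 to compound 3 (0.18 log units; within the scatter), and this too stays within the scatter. Nothing available here explains either result.

The compounds shown leave open whether a plain phenyl or an aminophenyl group in place of 3,4,5-trimethoxyphenyl would shift the number beyond the scatter. They also leave open whether a longer chain on the amine nitrogen would do so.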